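A few compounds are considered here, and "the series" means these few. Any claim that something is new, unique, unknown or untested is made for them only; others in the source may bear on it.

Measured so far:
compound 1 `N#C/C(=C\c1cc(O)c(O)c([N+](=O)[O-])c1)C(=O)N1CCCCC1` — in a functional assay on Bel-7402 cells (Homo sapiens) for antiproliferative activity, read by MTT assay (a lower number here means a stronger inhibitor, a higher number a weaker inhibitor), compound 1 gives > 100 ug/mL, an assay limit rather than a number.
compound 2 `N#C/C(=C\c1cc(O)c(O)c([N+](=O)[O-])c1)C(=O)N1CCOCC1` — in this assay compound 2 gives > 100 ug/mL, likewise a limit.

Compound 2 thus stands only at a limit in this assay; no number places it more closely. Compound 1 sits at the same boundary (the limit of > 100 ug/mL in this assay, at which 2 of the 2 values shown sit), so both measured values are limits. Among the measured compounds shown here, the single step, a step that the two limits leave unreadable from compound 1 to compound 2, is left unreadable by the two limits and carries no size forward.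

Compound 3 `N#C/C(=C\c1cc(O)c(O)c([N+](=O)[O-])c1)C(N)=O` differs from compound 2 by amino in place of morpholin-4-yl on a carbonyl carbon. For the measured compounds named here, the only measured step bearing on this position is the one just described, and since its size is not readable, no direction or size beyond the scatter can be set for the change to compound 3.

Compound 3 is therefore expected to give about 150 ug/mL in this assay, with a range from 60 ug/mL to 400 ug/mL, most likely reported again only as a limit. The expected step that the limit leaves unreadable from compound 2 to compound 3 amounts to no change the assay could read.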

Compound 3, half-maximal inhibitory concentration: > 100 ug/mL
Compound 3: no number, only a limit; the forecaster's own chance of this, stated with the estimate: 80%; the middle value is on the limit's open side.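

No new step can be read among compound 1, compound 2 and compound 3, as all three stand at the same boundary: the limit of > 100 ug/mL in this assay, at which 3 of the 3 values shown sit.

The compounds shown leave open how amino, morpholin-4-yl and piperidin-1-yl on the carbonyl carbon rank in this assay; no number places any of them.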